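Working notes on cytotoxicity across the shared core

The source may report more compounds than this note shows. Statements on the series, on what has been measured and on what is new or still open speak of the compounds shown alone.

In an ADME assay on HEL cells (Homo sapiens) for cytotoxicity, with a stated time of 3 days (on this read-out lower numbers stand for higher toxicity in this test and higher numbers for lower toxicity in this test), compound 2 `Cc1cc(-c2ccc(C#N)cc2)cn2c(CSCCc3ccccc3)cnc12` gives 10.6 ug/mL, the lowest of the two numbers shown; compound 3 `Cc1cc(-c2ccccc2)c2ncc(CSCCc3ccccc3)n2c1` gives 33 ug/mL, a gap beyond the scatter. Compound 1 `COc1cccc(-c2cc(C)cn3c(CSCCc4ccccc4)cnc23)c1` reaches only the limit > 50 ug/mL in this assay, and that is the limit of > 50 ug/mL in this assay, at which 1 of the 3 values shown sits. Among the compounds with values here, the one measured step, an at least 1.5-fold lower number from compound 1 to compound 3 (0.18 log units; that floor lies within the scatter), alters the same phenyl ring as the step to compound 4 `Cc1cc(-c2ccccc2O)cn2c(CSCCc3ccccc3)cnc12`, which brings (2-hydroxyphenyl in place of 4-cyanophenyl on an aromatic carbon). That measured step stayed within the scatter, so substitution on this ring has so far moved this assay little, although compound 2 sits clearly below compound 3. Removing the nitrile, compound 4 is expected to move back up, a 2.6-fold higher number from compound 2 to compound 4 (0.42 log units; beyond the scatter). Compound 4 is therefore estimated at 28 ug/mL, between 11 ug/mL and 60 ug/mL.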

Compound 4, half-maximal cytotoxic concentration: > 50 ug/mL
Compound 4: only a limit was reported (the forecaster's own chance of this, stated with the estimate: 25%); at least 1.7-fold (0.25 log units) between middle value and limit.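

In this assay, within the data shown here, 2-hydroxyphenyl in place of 4-cyanophenyl gives an at least 4.7-fold higher number from compound 2 to compound 4 (0.67 log units; beyond the scatter), so the group on this aromatic carbon can move the read-out beyond the scatter, which the one earlier step did not show. Compound 4 stands at a limit of the assay, not a number: the limit of > 50 ug/mL in this assay, at which 2 of the 4 values shown sit.

This single change removes the nitrile and brings in the hydroxy group, so the compounds shown do not separate the two. Going by these compounds, how an amine or a carboxylic acid on this phenyl ring would read in this assay also remains open.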